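Predicting Compound 4 from Three Aryl Variants

This account rests on a few compounds, and the source may have more. Where it says the series, first, only, none or still open, it means among the compounds named here.

Compound 1 `CCC1=C(O)c2c(oc(-c3ccc(C(F)(F)F)cc3)cc2=O)C(CC)(CC)C1=O` gives 10.4 uM in a functional assay on KBVIN cells (Homo sapiens) for antiproliferative activity, read by sulforhodamine B assay, with a stated time of 3 days; a higher number here means that more compound is needed for the effect, a lower number that less compound is needed. Compound 2 `CCCOc1ccc(-c2cc(=O)c3c(o2)C(CC)(CC)C(=O)C(CC)=C3O)cc1` gives 29.2 uM. Compound 3 `CCC1=C(O)c2c(oc(-c3ccc(CBr)cc3)cc2=O)C(CC)(CC)C1=O` gives 27.9 uM.

Compound 3 stands second highest of the three numbers: its nearest neighbour is compound 2, with a 1.0-fold lower number from compound 2 to compound 3 (0.02 log units; within the scatter), while compound 1 lies clearly lower, as a 2.7-fold higher number from compound 1 to compound 3 (0.43 log units; beyond the scatter) shows. Compound 4 `CCC1=C(O)c2c(oc(-c3ccc(OC)c(F)c3)cc2=O)C(CC)(CC)C1=O` differs from compound 3 in one place: 3-fluoro-4-methoxyphenyl in place of 4-(bromomethyl)phenyl on an aromatic carbon. For the measured compounds named here, no measured step covers this exact swap. The closest guide is a 1.0-fold lower number from compound 2 to compound 3 (0.02 log units; within the scatter), where exchanging propoxy for bromomethyl left the number essentially unchanged; only trifluoromethyl stood apart, through a 2.8-fold higher number from compound 1 to compound 2 (0.45 log units; beyond the scatter) and a 2.7-fold higher number from compound 1 to compound 3 (0.43 log units; beyond the scatter). The step of a 1.3-fold lower number from compound 3 to compound 4 (0.10 log units; within the scatter) is therefore expected to stay within the scatter. Compound 4 is estimated at 22 uM, in the range 8 uM to 55 uM.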

Compound 4, concentration for half-maximal effect: 0.1 uM
The estimate for compound 4 lay 220-fold (2.34 log units) above the measured number, outside the stated range (below it).
By their numbers in this assay, from the lowest: compound 4; then compound 1; then compounds 3 and 2 (each within the scatter of the next).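

The earlier swaps at this position, on the aromatic carbon next to the ring oxygen, moved the number modestly or not beyond the scatter, but in this assay there is a 280-fold lower number from compound 3 to compound 4 (2.45 log units; beyond the scatter). The group here can therefore change the result far more than those swaps suggested. Nothing measured here explains why this change has so large an effect.

Whether the fluorine, the methoxy or only the two together account for this step stays open. As far as these compounds go, how an amine or a carboxylic acid on the same phenyl ring would read also stays open.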